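The compounds below may be only part of what the source reports. "The series", "measured", "known", "first", "only" and "open" are said of these compounds alone.

Compound 1 `Cc1ccc(OCC(=O)N(Cc2cccs2)c2cccnc2)cc1` gives 198 nM in an assay on HEK293 cells for agonist activity at transient receptor potential cation channel subfamily M member 8 (Homo sapiens), read by fluorescence and calcium flux, with a stated time of 15 min; on this read-out lower numbers stand for an effect already at smaller amounts and higher numbers for an effect only at larger amounts of compound. Compound 2 `CCN(Cc1cccs1)C(=O)COc1ccc(F)cc1` gives 422 nM in this assay.

Of these two numbers compound 1 has the lower one; compound 2 sits above it by a gap beyond the usual scatter. Compound 3 `Cc1ccc(OCC(=O)N(Cc2cccs2)c2ccncc2)cc1` has not yet been measured. It differs from compound 1 in one place: pyridin-4-yl in place of pyridin-3-yl on an amide-type nitrogen. The two rings hold the same atoms, joined differently. Within the data shown here, no measured pair shows the effect of such a swap, so the expected step is small, at most around the edge of the scatter, if anything toward a higher number. Compound 3 is therefore expected at 300 nM, within 100 nM to 900 nM, meaning an estimated step of a 1.5-fold higher number from compound 1 to compound 3 (0.18 log units; within the scatter).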

Compound 3, half-maximal effective concentration: 52 nM
Compound 3: the middle estimate sits 5.8-fold (0.76 log units) above what was measured; the whole stated range lies above it.
By their numbers in this assay, from the lowest: compound 3; then compound 1; then compound 2.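

In this assay, pyridin-4-yl in place of pyridin-3-yl on the amide-type nitrogen gives a 3.8-fold lower number from compound 1 to compound 3 (0.58 log units; beyond the scatter). This shows that the position responds to how the ring is joined, even though both rings hold the same atoms and the same counted features. No measurement at hand says what lies behind this step.

From the compounds shown here alone, it remains open how pyridin-2-yl or a plain phenyl group would behave on this nitrogen. Going by these compounds, it is also open whether the ring nitrogen is needed at all to reach the number of compound 3.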